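The compounds below may be only part of what the source reports. "The series", "measured", "known", "first", "only" and "open" are said of these compounds alone.

Working notes on the series. In an assay with sodium-dependent dopamine transporter (Rattus norvegicus) as the target (on this read-out higher numbers stand for weaker inhibition and lower numbers for stronger inhibition), compound 1 `COC(=O)C1C2CCC3CCC1N(C/C2=C\c1ccc(-c2ccc(C)cc2)cc1)C3` gives 214 nM. Compound 2 `COC(=O)C1C2CCC3CCC1N(C/C2=C\c1ccc(-c2ccc(N(C)C)cc2)cc1)C3` gives 1050 nM in this assay, and compound 3 `COC(=O)C1C2CCC3CCC1N(C/C2=C\c1ccc(-c2cccs2)cc1)C3` gives 155 nM. Compound 3 shows the lowest number of the three, though its gap to compound 1 is within the scatter, as a 1.4-fold lower number from compound 1 to compound 3 (0.14 log units; within the scatter) shows; by contrast a 4.9-fold higher number from compound 1 to compound 2 (0.69 log units; beyond the scatter) and a 6.8-fold lower number from compound 2 to compound 3 (0.83 log units; beyond the scatter) lie beyond it. Compound 4 `COC(=O)C1C2CCC3CCC1N(C/C2=C\c1ccc(-c2ccc(C)s2)cc1)C3` differs from compound 3 by methyl in place of hydrogen on an aromatic carbon. Among the measured compounds shown here, none of the measured steps touches this ring position; the two steps beyond the scatter exchange whole aryl groups. The added methyl is therefore expected to give a 1.0-fold lower number from compound 3 to compound 4 (0.01 log units; within the scatter) in this assay, nothing beyond the scatter. Compound 4 is estimated at 150 nM, between 60 nM and 400 nM.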

Compound 4, inhibition constant: 674 nM
Beside the measured number, compound 4's estimate is 4.5-fold (0.65 log units) below it; measured number above the stated range.
By their numbers in this assay, from the lowest: compounds 3 and 1 (each within the scatter of the next); then compounds 4 and 2 (each within the scatter of the next).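

The aromatic carbon next to the ring sulfur is not indifferent in this assay: the single added methyl, thiophen-2-yl to 5-methylthiophen-2-yl, moves the number beyond the scatter (a 4.3-fold higher number from compound 3 to compound 4 (0.64 log units; beyond the scatter)). Thiophen-2-yl and 4-methylphenyl had stood within the scatter of each other, but 5-methylthiophen-2-yl separates from 4-methylphenyl (a 3.1-fold higher number from compound 1 to compound 4 (0.50 log units; beyond the scatter)) and stays within the scatter of 4-(dimethylamino)phenyl (a 1.6-fold lower number from compound 2 to compound 4 (0.19 log units; within the scatter)). No measurement shown accounts for the methyl step.

Going by these compounds, whether this step belongs to methyl alone or to any group on this carbon stays open; a chlorine, a methoxy or an ethyl there would separate the two.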